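A few compounds are considered here, and "the series" means these few. Any claim that something is new, unique, unknown or untested is made for them only; others in the source may bear on it.

Measured compounds in a functional assay on HEK293 cells for positive allosteric modulation of metabotropic glutamate receptor 5 (Rattus norvegicus), read by fluorescence and calcium flux; on this read-out higher numbers stand for larger maximal responses and lower numbers for smaller maximal responses:
compound 1 `C[C@@H](NC(=O)c1ccc(C#Cc2ccccc2F)cn1)C(C)(C)O`, 60%
compound 2 `Cc1ccc(C#Cc2ccc(C(=O)N[C@H](C)C(C)(C)O)nc2)cc1`, 63.1%
compound 3 `C[C@@H](NC(=O)c1ccc(C#Cc2cccnc2)cn1)C(C)(C)O`, 71.5%

Compound 3 gives the highest of the three numbers in this assay. Nearest to it stands the step of a number 8.4 percentage points higher from compound 2 to compound 3 (within the scatter); furthest, a number 11.5 percentage points higher from compound 1 to compound 3 (beyond the scatter). Only the latter clears the scatter, so compound 3 is not called the strongest of the set. The remaining step, a number 3.1 percentage points higher from compound 1 to compound 2 (within the scatter), also stays within the scatter.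

Compound 4 `C[C@@H](NC(=O)c1ccc(C#Cc2ccncc2)cn1)C(C)(C)O` is unmeasured. It differs from compound 3 by pyridin-4-yl in place of pyridin-3-yl on a triple-bonded carbon. All three measured steps exchange one whole aryl group on the triple-bonded carbon for another; none moves a ring nitrogen within an otherwise unchanged ring, so none bears directly on this change. They do show how wide the maximal response has varied across the series: the largest step, from compound 1 to compound 3, is modest, and the other two lie inside the scatter. No direction can be read for the step to compound 4, and its closest analogue, compound 3, holds the top value of the set. Compound 4 is therefore expected to give 68% in this assay, within 56% to 80%. The expected step is a number 3.5 percentage points lower from compound 3 to compound 4 (within the scatter), not beyond the scatter.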

Compound 4, largest response reached (reported as efficacy), in percent of the reference or control that the assay uses: 66.6%
Beside the measured number, compound 4's estimate is 1.4 percentage points above it; low and high end bracket the measured number.
By their numbers in this assay, from the lowest: compounds 1, 2, 4 and 3 (each within the scatter of the next, the first and the last beyond it).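

In this assay, the exchange of pyridin-3-yl for pyridin-4-yl on the triple-bonded carbon gives a number 4.9 percentage points lower from compound 3 to compound 4 (within the scatter) and is the only step shown that keeps the same atoms in the entering and leaving groups, so the response at this position tolerates this rearrangement within the scatter. The steps of a number 3.5 percentage points higher from compound 2 to compound 4 (within the scatter) and a number 6.6 percentage points higher from compound 1 to compound 4 (within the scatter) also stay within the scatter, so compound 4 does not share the separation from compound 1 that compound 3 shows, and the two pyridine compounds together give no firm rule that a pyridine on the triple-bonded carbon sets the series apart from the substituted phenyl compounds. No supporting measurement accounts for these differences in response.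

Still open, as far as these compounds go, is how pyridin-2-yl, pyrimidin-5-yl or an aminopyridine on the triple-bonded carbon would behave in this assay beside the two pyridine compounds. The compounds shown also leave open whether the same reading would hold with a longer chain or an amine in place of the hydroxyl-bearing amide side chain, which stays unchanged throughout.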